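Methoxy for Methyl on a Urea Pair

The source may hold more compounds than are shown below. What is called first, only, known or untested is meant among the compounds shown, and "the series" means these compounds.

Compound 2, with the structure `Cc1ccccc1NC(=O)N[C@@H](C)c1ccccc1`, was tested in an ADME assay on the whole organism with Oryza sativa as the target, tested at 10 uM (on this read-out lower numbers stand for a stronger effect and higher numbers for a weaker effect at the one concentration tested), where it gives 99%. Compound 1, `Cc1ccccc1NC(=O)N[C@H](C)c1ccccc1`, differs from it only in configuration (the fact that compounds 1 and 2 differ only in the configuration as drawn), and in the same assay compound 1 gives 99%; the step of no change at the digits printed from compound 1 to compound 2 (within the scatter) shows no change at the digits printed. Compound 3, `CCCCCCCc1ccc(NC(=O)N[C@H](C)c2ccccc2)cc1`, gives 100%. Compound 2 therefore stands level with compound 1, the two together being the lowest of the three numbers, while compound 3 lies a single point higher, which is within the scatter; all three readings sit near the top of the scale.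

Compound 4, `COc1ccccc1NC(=O)N[C@@H](C)c1ccccc1`, has not yet been measured. It differs from compound 2 by methoxy in place of methyl on an aromatic carbon. Within the data shown here, no measured step bears on a change of this kind: the only recorded step is the configurational one, and it was flat. Compounds 2 and 3 differ in more than one place, so their values show only that both sit near the top of the range. The step expected here, a number 1 percentage points lower from compound 2 to compound 4 (within the scatter), is none beyond the scatter. Compound 4 is accordingly estimated at 98%, with a range from 88% to 100%.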

Compound 4, a percentage reported as activity, at one concentration (the size of the read-out at that concentration, not a potency): 95%
Beside the measured number, compound 4's estimate is 3 percentage points above it, and the stated range covers the measured number.
By their numbers in this assay, from the lowest: compounds 4, 1, 2 and 3 (each within the scatter of the next).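

In this assay, among these compounds, the exchange of methyl for methoxy on an aromatic carbon, ortho to a large group, gives a number 4 percentage points lower from compound 2 to compound 4 (within the scatter), which is the first reading of any change to a group at this place on the ring. The entering methoxy adds one oxygen and one hydrogen-bond acceptor, yet this exchange stays within the usual scatter, so the pair gives no sign that the read-out responds to this particular change. The one established fact about these compounds concerns configuration alone and has no bearing on an exchange of groups, so no explanation can be offered for this result.

The compounds shown leave open whether a group of a different kind at this place, such as an amine or a carboxylic acid, would move the reading beyond the scatter. Among the compounds shown here, they also leave open whether methoxy would behave in the same way on the opposite configuration of the stereocentre, the one drawn in compound 1.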